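The compounds below may be only part of what the source reports. "The series", "measured", "known", "first", "only" and "open" are said of these compounds alone.

Working notes on the series. In an assay on HEK293 cells for inhibition of N-acylethanolamine-hydrolyzing acid amidase (Homo sapiens), read by fluorescence, with stated times of 10 min and 50 min (on this read-out lower numbers stand for stronger inhibition and higher numbers for weaker inhibition), compound 1 `CCCCCON1C(=O)[C@@H](NC(=O)OCCCCC2CCCCC2)[C@@H]1C` gives 387 nM, the second highest of the three numbers in hand. Compound 2 `C[C@H]1[C@H](NC(=O)OCCCCC2CCCCC2)C(=O)N1OCCCCc1ccccc1` gives 1240 nM in this assay, and compound 3 `C[C@H]1[C@H](NC(=O)OCCCCC2CCCCC2)C(=O)N1Oc1ccccc1` gives 23 nM. The measured steps run a 3.2-fold higher number from compound 1 to compound 2 (0.51 log units; beyond the scatter), a 17-fold lower number from compound 1 to compound 3 (1.23 log units; beyond the scatter) and a 54-fold lower number from compound 2 to compound 3 (1.73 log units; beyond the scatter), so the exchange of the group on the oxygen is the move that has shifted the numbers most in this assay.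

Compound 4 `C[C@H]1[C@H](NC(=O)OCCCCC2CCCCC2)C(=O)N1Oc1ccc(C(F)(F)F)cc1` has not been measured in this assay. It differs from compound 1 in one place: 4-(trifluoromethyl)phenyl in place of pentyl on an oxygen. Among the compounds with values here, the step that bears on it most directly is the one from compound 1 to compound 3, where phenyl in place of pentyl on the same oxygen gave a 17-fold lower number from compound 1 to compound 3 (1.23 log units; beyond the scatter); the step from compound 2 to compound 3, a 54-fold lower number from compound 2 to compound 3 (1.73 log units; beyond the scatter), points the same way. Within the data shown here, no measured pair shows what the trifluoromethyl on the phenyl does, so the expectation rests on the phenyl-for-pentyl exchange alone and carries a wide range. A large step towards a lower number is therefore expected, a 15-fold lower number from compound 1 to compound 4 (1.19 log units; beyond the scatter), landing compound 4 near compound 3. The estimate for compound 4 in this assay is 25 nM, with a range from 6 nM to 110 nM.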

Compound 4, half-maximal inhibitory concentration: 31 nM
Compound 4: the middle estimate sits 1.2-fold (0.09 log units) below what was measured, and the stated range covers the measured number.
By their numbers in this assay, from the lowest: compounds 3 and 4 (each within the scatter of the next); then compound 1; then compound 2.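

Trifluoromethyl in place of hydrogen on an aromatic carbon is the first change made on the phenyl itself, and it gives a 1.3-fold higher number from compound 3 to compound 4 (0.13 log units; within the scatter) in this assay, so this substituent leaves the number unmoved within the usual variation. The advantage of an aromatic group on this oxygen therefore extends beyond unsubstituted phenyl to the larger 4-(trifluoromethyl)phenyl, with a 12-fold lower number from compound 1 to compound 4 (1.10 log units; beyond the scatter) against the pentyl group and a 40-fold lower number from compound 2 to compound 4 (1.60 log units; beyond the scatter) against the 4-phenylbutyl group. Nothing available accounts for either the large steps or the flat one.

As far as these compounds go, whether an amine or a carboxylic acid on the phenyl would also leave the number in place remains open, as does whether a benzyl group on the oxygen would track with phenyl or with the two chains. The rest of the structure is shared by all four compounds, so it is also unknown whether these steps would carry over to a shorter chain ending in the cyclohexyl ring.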